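The source may hold more compounds than are shown below. What is called first, only, known or untested is meant among the compounds shown, and "the series" means these compounds.

Measured so far in an ADME assay on a cell-free system (plasma, Mus musculus); on this read-out higher numbers stand for a larger free fraction and lower numbers for a smaller free fraction:

- compound 1 `CN(C)S(=O)(=O)c1cncc(C#Cc2cc(Cl)ccc2OCC(=O)O)c1`: 0.034
- compound 2 `Cc1ccc(S(=O)(=O)N(C)C(C)C)cc1C#Cc1cc(Cl)ccc1OCC(=O)O`: 0.005

Of these two, compound 2 has the lower number, at 0.005, and the gap up to compound 1 lies beyond the scatter of repeated measurements. The next compound, compound 3 `Cc1ccc(S(=O)(=O)N(C)C)cc1C#Cc1cc(Cl)ccc1OCC(=O)O`, has not yet been measured. It keeps compound 2 unchanged except for one swap: methyl in place of isopropyl on a sulfonamide nitrogen. For the measured compounds named here, no measured pair shows this change on its own, so the forecast is uncertain. Compound 1 also carries dimethylsulfamoyl and gives 0.034 in this assay, which points towards a modest rise. The expected change is a 1.8-fold higher number from compound 2 to compound 3 (0.26 log units; within the scatter), close to the edge of the scatter. For compound 3 the estimated value is 0.009, with an expected range of 0.004 to 0.02.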

Compound 3, unbound fraction: 0.01
Beside the measured number, compound 3's estimate is 1.1-fold (0.05 log units) below it; measured number inside the range.
By their numbers in this assay, from the lowest: compounds 2 and 3 (each within the scatter of the next); then compound 1.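

In this assay, methyl in place of isopropyl on a sulfonamide nitrogen, seen on its own in this pair, gives a 2.0-fold higher number from compound 2 to compound 3 (0.30 log units; within the scatter) and so cannot be told apart from the spread of repeat measurements. Within these two compounds, then, the choice between isopropyl and methyl at this position does not clearly separate their free fractions. Nothing available gives a measured reason for this result.

Going by these compounds, whether ethyl, a plain hydrogen on that nitrogen, or a morpholine ring in place of the whole dimethylamino part would behave the same way stays open. Compound 1 differs from compound 3 in more than one place, so the value of compound 1 at 0.034 cannot be tied to any single part of its structure.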